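Aryl swap at the limit: compound 3 to compound 4

The source may hold more compounds than are shown below. What is called first, only, known or untested is meant among the compounds shown, and "the series" means these compounds.

Measured in a functional assay on LNCaP cells (Homo sapiens) for antiproliferative activity, read by MTT assay, with a stated time of 24 h; on this read-out lower numbers stand for stronger inhibition and higher numbers for weaker inhibition:
- compound 1 `COc1ccc(-c2noc(-c3ccccc3)n2)cc1OC1CCCC1`: > 1000000 nM (a limit)
- compound 2 `COc1ccc(-c2noc(C3CCCN3)n2)cc1OC1CCCC1`: 43 nM
- compound 3 `COc1ccc(-c2noc(-c3cccnc3)n2)cc1OC1CCCC1`: > 1000000 nM (a limit)

Compound 3 has no number, only a limit, and (the limit of > 1000000 nM in this assay, at which 2 of the 3 values shown sit). Compound 4 `COc1ccc(-c2noc(-c3ccc(O)cc3)n2)cc1OC1CCCC1` carries 4-hydroxyphenyl in place of pyridin-3-yl on an aromatic carbon. The closest measured step, a step that the two limits leave unreadable from compound 1 to compound 3, cannot be sized. The large steps, an at least 23000-fold lower number from compound 1 to compound 2 (4.36 log units; beyond the scatter) and an at least 23000-fold higher number from compound 2 to compound 3 (4.36 log units; beyond the scatter), both involve pyrrolidin-2-yl, which compound 4 lacks. With a six-membered aromatic ring again in place, little change is expected in this assay, and any readable change could only be towards a lower number. The expected step is an at least 2.0-fold lower number from compound 3 to compound 4 (0.30 log units; that floor lies within the scatter). For compound 4 the estimate is 500000 nM, with an expected range of 20000 nM to 2000000 nM.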

Compound 4, half-maximal inhibitory concentration: 860 nM
Estimate against measurement, compound 4: 580-fold (2.76 log units) above; measured number outside the range, below it.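

In this assay an aromatic ring on this carbon is not itself the barrier: hydroxy on the phenyl gives an at least 1100-fold lower number from compound 1 to compound 4 (3.06 log units; beyond the scatter) and 4-hydroxyphenyl in place of pyridin-3-yl gives an at least 1100-fold lower number from compound 3 to compound 4 (3.06 log units; beyond the scatter) as a second route to the same compound. Pyrrolidin-2-yl still holds the lower number, with a 20-fold higher number from compound 2 to compound 4 (1.30 log units; beyond the scatter) on going over to 4-hydroxyphenyl. The first two steps are floors, as each starts from a compound held at a limit: the limit of > 1000000 nM in this assay, at which 2 of the 4 values shown sit.

Still open, on these data alone, is whether methoxy, an amine or a carboxylic acid in place of the hydroxy would keep this gain.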